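A Carboxylic Acid Replaces the Aryl Amide Group

The source may report more compounds than this note shows. Statements on the series, on what has been measured and on what is new or still open speak of the compounds shown alone.

Compound 1 `CCn1c(C(=O)NCCN)ccc1C(CC)(CC)c1ccc(OCCC(O)(CC)CC)c(C)c1`: 2420 nM
Compound 2 `CCn1c(C(=O)Nc2ccc(OC(F)(F)F)cc2)ccc1C(CC)(CC)c1ccc(OCCC(O)(CC)CC)c(C)c1`: > 50000 nM

In a functional assay on PC-3 cells (Homo sapiens) for antiproliferative activity, read by MTT assay, with a stated time of 48 h (on this read-out higher numbers stand for weaker inhibition and lower numbers for stronger inhibition), compound 2 gives > 50000 nM, which is a limit of the assay and not a number. Compound 3 `CCC(C)C(NC(=O)c1ccc(C(CC)(CC)c2ccc(OCCC(O)(CC)CC)c(C)c2)n1CC)C(=O)O` keeps the shared core but places 1-carboxy-2-methylbutyl in place of 4-(trifluoromethoxy)phenyl on an amide-type nitrogen. Within the data shown here, only one measured step bears on this change: an at least 20-fold higher number from compound 1 to compound 2 (1.31 log units; beyond the scatter), a large step that came with the entry of the same 4-(trifluoromethoxy)phenyl group. Compound 3 loses that group, so part of this step may be reversed, although the incoming group differs from the 2-aminoethyl of compound 1. A lower number is therefore expected in this assay, but one step gives weak guidance and the result may still reach the limit. The expected change is an at least 3.3-fold lower number from compound 2 to compound 3 (0.52 log units; beyond the scatter). Compound 3 is estimated at 15000 nM, with an expected range of 4000 nM to 50000 nM.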

Compound 3, half-maximal inhibitory concentration: 13800 nM
Compound 3: the middle estimate sits 1.1-fold (0.04 log units) above what was measured; low and high end bracket the measured number.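

In this assay, putting the ring-free 1-carboxy-2-methylbutyl in place of the aromatic 4-(trifluoromethoxy)phenyl on the amide-type nitrogen restores a measurable value, with an at least 3.6-fold lower number from compound 2 to compound 3 (0.55 log units; beyond the scatter). Compound 2 stands at a limit of the assay and not at a number: the limit of > 50000 nM in this assay, at which 1 of the 3 values shown sits. The new group does not match the 2-aminoethyl of the first compound, with a 5.7-fold higher number from compound 1 to compound 3 (0.76 log units; beyond the scatter), so even two groups without a ring give clearly different results at this nitrogen.

The compounds shown cannot tell whether that gap follows from swapping an amine for a carboxylic acid or from the branched carbon chain that comes with it. A plain butyl chain or a carboxymethyl group on the same nitrogen would help separate these two parts.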